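From Ethoxy to Methylsulfanyl: Expectations for Compound 4

The source may hold more compounds than are shown below. What is called first, only, known or untested is meant among the compounds shown, and "the series" means these compounds.

In a functional assay on the whole organism (strain Sprague-Dawley) for inhibition, with Rattus norvegicus as the target, with a stated time of 10 min (on this read-out higher numbers stand for an effect only at larger amounts of compound and lower numbers for an effect already at smaller amounts), three compounds sharing one core have been measured. Compound 1 `CCOc1ccccc1-c1ncc(C(=O)O)c(=O)[nH]1` gives 0.5 mg/kg. Compound 2 `CCCCCOc1ccccc1-c1ncc(C(=O)O)c(=O)[nH]1` gives 3 mg/kg, and compound 3 `CCOC(=O)c1cnc(-c2ccccc2OCC)[nH]c1=O` gives 2 mg/kg. Compound 3 thus holds the second highest of the three numbers: its value lies within the usual scatter of that of compound 2, while against compound 1 the step of a 4.0-fold higher number from compound 1 to compound 3 (0.60 log units; beyond the scatter) lies beyond the scatter.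

The unmeasured compound 4 `CCOC(=O)c1cnc(-c2ccccc2SC)[nH]c1=O` differs from compound 3 in one place: methylsulfanyl in place of ethoxy on an aromatic carbon.

Two measured steps give some guidance. The step of a 6.0-fold higher number from compound 1 to compound 2 (0.78 log units; beyond the scatter) concerns the same aromatic position, where a longer chain on the oxygen raised the number modestly. The step of a 4.0-fold higher number from compound 1 to compound 3 (0.60 log units; beyond the scatter) concerns the ester and separates compound 3 from compound 1. Neither step exchanges the oxygen of the ethoxy group for sulfur, so the direction of the present change is not settled by the data. Because the step of a 6.0-fold higher number from compound 1 to compound 2 (0.78 log units; beyond the scatter) shows that altering the group at this aromatic position raised the number only modestly, the writer expects a similarly small shift, a step of a 1.5-fold higher number from compound 3 to compound 4 (0.18 log units; within the scatter). Compound 4 is estimated at 3 mg/kg, with a range from 1 mg/kg to 9 mg/kg.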

Compound 4, dose for 50% inhibition: > 25 mg/kg
Compound 4: only a limit was reported; the forecaster's own chance of this, stated with the estimate: 10%; at least 8.3-fold (0.92 log units) between middle value and limit.
By their numbers in this assay, from the lowest: compound 1; then compounds 3 and 2 (each within the scatter of the next). At a limit, above all of these: compound 4.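

Compound 4 is recorded only as a limit, not as a number: the limit of > 25 mg/kg in this assay, at which 1 of the 4 values shown sits.

Exchanging ethoxy for methylsulfanyl on this aromatic carbon comes with an at least 12-fold higher number from compound 3 to compound 4 (1.09 log units; beyond the scatter), a large step in this assay, whereas the earlier change at this position, which lengthened the chain and kept the oxygen, gave a step printed as modest: a 6.0-fold higher number from compound 1 to compound 2 (0.78 log units; beyond the scatter). The position therefore proves sensitive to this exchange in a way that the chain change on the acid did not reveal, although the two changes were made on different compounds, one an acid and one an ethyl ester, and so describe the position only within those pairs.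

How far compound 4 lies beyond its limit cannot be told, and neither can whether the sulfur or the smaller size of the group goes with the loss, since the exchange alters both at once. Methoxy or ethylsulfanyl on this carbon would separate the two, and methylsulfanyl on the carboxylic acid of compound 1 would show whether the change holds without the ethyl ester.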